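A few compounds are considered here, and "the series" means these few. Any claim that something is new, unique, unknown or untested is made for them only; others in the source may bear on it.

Compound 3 `Cc1cn([C@@H]2C[C@H](O)[C@@H](CNC(=O)Nc3ccc(C(C)(C)C)cc3)O2)c(=O)[nH]c1=O` is one of three close relatives tested in an ADME assay on MRC5 cells (Homo sapiens) for cytotoxicity; on this read-out lower numbers stand for higher toxicity in this test and higher numbers for lower toxicity in this test. In this assay compound 3 gives only a limit, > 50000 nM, not a measured number. Its neighbour compound 1 `Cc1cn([C@@H]2C[C@H](O)[C@@H](CNC(=O)Nc3ccc(Cl)cc3)O2)c(=O)[nH]c1=O` likewise reaches only the limit of > 50000 nM. Compound 2 `COc1ccc(NC(=O)NC[C@H]2O[C@H](n3cc(C)c(=O)[nH]c3=O)C[C@@H]2O)cc1` also stops at the limit of > 50000 nM. Because all three sit at the limit of > 50000 nM in this assay, at which 3 of the 3 values shown sit, the change from compound 1 to compound 3 a step that the two limits leave unreadable from compound 1 to compound 3 and that from compound 2 to compound 3 a step that the two limits leave unreadable from compound 2 to compound 3 tell nothing about how a group on that aromatic carbon moves toxicity; the cells simply tolerated every compound up to the highest concentration tested.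

Compound 4 `Cc1ccc2nc(-c3ccc(NC(=O)NC[C@H]4O[C@H](n5cc(C)c(=O)[nH]c5=O)C[C@@H]4O)cc3)sc2c1` differs from compound 3 by 6-methyl-1,3-benzothiazol-2-yl in place of tert-butyl on an aromatic carbon. The group that enters is much larger than the tert-butyl it replaces and brings two aromatic rings, so the unreadable earlier steps give no guide to its size or direction.

With nothing measurable to build on, the expectation is that compound 4 stays near the limit, and the step from compound 3 to compound 4 is estimated at an at least 1.2-fold lower number from compound 3 to compound 4 (0.09 log units; that floor lies within the scatter). Compound 4 is therefore expected to show about 40000 nM in this assay, within a range from 10000 nM to 100000 nM.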

Compound 4, half-maximal cytotoxic concentration: > 50000 nM
Compound 4 ended at the assay's limit; the forecaster's own chance of this, stated with the estimate: 50%; middle value at least 1.2-fold (0.09 log units) away from the limit.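

In this assay compound 4 gives > 50000 nM as a limit only. Its steps from compound 1, compound 2 and compound 3 therefore cannot be read, as all four compounds share that limit: the limit of > 50000 nM in this assay, at which 4 of the 4 values shown sit. The compounds shown leave open what concentration, if any, harms these cells, and whether any group on that aromatic carbon changes toxicity.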